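Fluoro to carboxy on the aromatic ring

The compounds below may be only part of what the source reports. "The series", "measured", "known", "first", "only" and "open" are said of these compounds alone.

Measured in a functional assay on HeLa cells (Homo sapiens) for cytotoxicity, read by MTT assay, with a stated time of 48 h; a higher number here means a weaker inhibitor, a lower number a stronger inhibitor:
compound 1 `COc1cccc(OC)c1/C=C/[C@](C)(O)CC[C@@H]1[C@@]2(C)CCCC(C)(C)[C@@H]2CC[C@@]1(C)O`: 48200 nM
compound 2 `CC1(C)CCC[C@]2(C)[C@@H](CC[C@@](C)(O)/C=C/c3ccc(F)cc3)[C@](C)(O)CC[C@@H]12`: 3460 nM

Compound 2 holds the lower of the two numbers. The next compound is compound 3 `CC1(C)CCC[C@]2(C)[C@@H](CC[C@@](C)(O)/C=C/c3ccc(C(=O)O)cc3)[C@](C)(O)CC[C@@H]12`, with carboxy in place of fluoro on an aromatic carbon, para to a large group: carboxy in place of fluoro on an aromatic carbon. Within the data shown here, only one measured step bears on this change: a 14-fold lower number from compound 1 to compound 2 (1.14 log units; beyond the scatter). That large step, which replaces 2,6-dimethoxyphenyl with 4-fluorophenyl, shows that the number in this assay can respond strongly to the aromatic substituents. Among the measured compounds shown here, no measured compound carries carboxy, so the direction is weakly supported. With compound 2 at the lower number, a moderate step towards a higher number is expected, smaller than the measured one. The expected change is a 2.9-fold higher number from compound 2 to compound 3 (0.46 log units; beyond the scatter). For compound 3 the estimated value is 10000 nM, with a range of 3000 nM to 40000 nM.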

Compound 3, half-maximal inhibitory concentration: 45400 nM
Compound 3: the middle estimate sits 4.5-fold (0.66 log units) below what was measured; the whole stated range lies below it.
By their numbers in this assay, from the lowest: compound 2; then compounds 3 and 1 (each within the scatter of the next).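

In this assay, the aromatic carbon para to a large group proves sensitive to a single exchange, carboxy in place of fluoro, with a 13-fold higher number from compound 2 to compound 3 (1.12 log units; beyond the scatter) as the result. The 4-carboxyphenyl and 2,6-dimethoxyphenyl compounds are not separated, with a 1.1-fold lower number from compound 1 to compound 3 (0.03 log units; within the scatter) lying within the scatter, so among these three compounds only compound 2 stands apart. No supporting data on hand account for the step.

Going by these compounds, it remains open whether fluoro is favourable in its own right or carboxy is unfavourable, as a single pair cannot separate the two. Chloro, a methyl ester or an amine at the same aromatic carbon would help to show which of these readings holds.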